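The source may report more compounds than this note shows. Statements on the series, on what has been measured and on what is new or still open speak of the compounds shown alone.

Measured so far in a physicochemical assay for lipophilicity, using the shake flask method, in phosphate buffer, measured as octanol-water partition, with a stated time of 30 min, at pH 7.4; a lower number here means a more polar compound, a higher number a more lipophilic compound:
- compound 1 `O=C(Nc1ccccc1)c1cnc(NCc2c(F)ccc3c2CCO3)n2cnnc12` gives 4.1
- compound 2 `Cn1cc(-c2cnc(NCc3c(F)ccc4c3CCO4)c3cn[nH]c(=O)c23)cn1` gives 2.7
- compound 3 `CC(=O)N1CCC(c2cnc(NCc3c(F)ccc4c3CCO4)c3cn[nH]c(=O)c23)CC1` gives 2.9

Among these three, compound 1 stands highest in this assay; compound 3 and compound 2 sit well below it, and the one measured step, a number 0.20 log units higher from compound 2 to compound 3 (within the scatter), lies within the scatter. Compound 4 `CN(C(=O)c1ccccc1)c1cnc(NCc2c(F)ccc3c2CCO3)n2cnnc12` differs from compound 1 in one place: benzoyl(methyl)amino in place of phenylcarbamoyl on an aromatic carbon. Going by the values given here, no measured step shows what happens in this assay when an amide hydrogen is replaced by a methyl in this way, so the expectation rests on compound 1 alone. For compound 4 the expected step is a number 0.20 log units lower from compound 1 to compound 4 (within the scatter), a change no larger than the scatter. The estimate for compound 4 in this assay is 3.9, with a range from 3.4 to 4.4.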

Compound 4, distribution coefficient: 2.4
Beside the measured number, compound 4's estimate is 1.50 log units above it; the whole stated range lies above it.
By their numbers in this assay, from the lowest: compounds 4, 2 and 3 (each within the scatter of the next, the first and the last beyond it); then compound 1.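

In this assay, benzoyl(methyl)amino in place of phenylcarbamoyl on this aromatic carbon gives a number 1.70 log units lower from compound 1 to compound 4 (beyond the scatter) and so counts as a large step. This position is therefore sensitive to the change, even though the entering group adds only one carbon and has no hydrogen-bond donor. Nothing measured here accounts for the drop.

Still open, on these data alone, is whether an ethyl group in place of the methyl on the amide nitrogen would give a step of similar size. Also open, as far as these compounds go, is whether the same swap would have a similar effect on the core of compound 2.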